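Swapping amino for hydroxy on a purine-free chain

The compounds below may be only part of what the source reports. "The series", "measured", "known", "first", "only" and "open" are said of these compounds alone.

Hmm, corrected title below.

Swapping Amino for Hydroxy on the Side Chain

Compound 1 (`OCCCCNc1nc(Nc2ccc(N3CCN(Cc4ccccc4)CC3)cc2)c2ncn(CCCO)c2n1`) gives > 40000 nM as a limit
Compound 2 (`NCCCCNc1nc(Nc2ccc(N3CCN(Cc4ccccc4)CC3)cc2)c2ncn(C3CCC(O)C3)c2n1`) gives 13200 nM as a number

For the measured compounds named here, in an ADME assay on BJ cells (Homo sapiens) for inhibition, read by fluorescence and resazurin assay, with a stated time of 72 h (on this read-out higher numbers stand for weaker inhibition of growth and lower numbers for stronger inhibition of growth), compound 2 gives 13200 nM as the only true number so far. Compound 3 (`OCCCCNc1nc(Nc2ccc(N3CCN(Cc4ccccc4)CC3)cc2)c2ncn(C3CCC(O)C3)c2n1`) differs from compound 2 in one place (hydroxy in place of amino on a saturated chain carbon, four bonds along the chain from a nitrogen on an aromatic ring): hydroxy in place of amino on a saturated chain carbon, four bonds along the chain from a nitrogen on an aromatic ring. Going by the values given here, no measured pair shows this change alone, so any forecast is indirect. Compound 1, which also carries hydroxy on that chain, reads > 40000 nM as a limit and not a number. On that basis, a moderate step towards weaker inhibition of growth is expected in this assay, and it may reach the limit. The estimated change is a 2.1-fold higher number from compound 2 to compound 3 (0.33 log units; beyond the scatter) as the expected step. For compound 3 the estimate is 28000 nM with an expected range of 13000 nM to 40000 nM in this measurement.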

Compound 3, concentration for 50% growth inhibition: 23800 nM
For compound 3 the middle estimate is 1.2-fold (0.07 log units) above the measured one, within the range that was stated.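

In this assay, for the compounds shown here, the pair of compound 2 and compound 3 isolates the exchange on the side chain for the first time, and it gives a 1.8-fold higher number from compound 2 to compound 3 (0.26 log units; within the scatter). Hydroxy in place of amino at this place therefore produces no change that can be told apart from repeat-measurement noise. The other one-place change, 3-hydroxycyclopentyl in place of 3-hydroxypropyl on an aromatic nitrogen, gives an at least 1.6-fold lower number from compound 1 to compound 3 (0.22 log units; that floor lies within the scatter), but compound 1 reads a limit and not a number, so the true size of that step remains unknown: the limit of > 40000 nM in this assay, at which 1 of the 3 values shown sits.

The compounds shown pair amino on the side chain only with 3-hydroxycyclopentyl, so it remains open whether the exchange would read the same alongside 3-hydroxypropyl. Also open, going by these compounds, is how a carboxylic acid or a longer chain at this place would read.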